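This account rests on a few compounds, and the source may have more. Where it says the series, first, only, none or still open, it means among the compounds named here.

Measured so far in a functional assay on KB cells (Homo sapiens) for cytotoxicity, read by sulforhodamine B assay; a higher number here means a weaker inhibitor, a lower number a stronger inhibitor:
compound 1 `C=C1[C@@H](OC(C)=O)C[C@@H]2[C@](C)(CO[Si](C)(C)C(C)(C)C)[C@H](OC(C)=O)CC[C@@]2(C)[C@@H]1C[C@@H](Nc1ccc(Br)cc1)C1=CCOC1=O` — 5230 nM
compound 2 `C=C1[C@@H](OC(C)=O)C[C@@H]2[C@](C)(COC=O)[C@H](OC(C)=O)CC[C@@]2(C)[C@@H]1C[C@@H](Nc1ccc(Br)cc1)C1=CCOC1=O` — 24000 nM

Compound 1 gives the lowest of the two numbers in this assay; the nearest is compound 2, reached by a 4.6-fold higher number from compound 1 to compound 2 (0.66 log units; beyond the scatter). That step replaces a group on an oxygen on a saturated carbon in the shared core and leaves the arylamine untouched.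

Compound 3 `C=C1[C@@H](OC(C)=O)C[C@@H]2[C@](C)(CO[Si](C)(C)C(C)(C)C)[C@H](OC(C)=O)CC[C@@]2(C)[C@@H]1C[C@@H](Nc1cccc2ccccc12)C1=CCOC1=O` keeps the silyl-bearing core of compound 1 and differs from it only at the arylamine: naphthalen-1-yl in place of 4-bromophenyl on an amine nitrogen. Going by the values given here, no measured step touches this position, so nothing in the two numbers bears directly on the change. Among the compounds with values here, the only known step, on the oxygen side of the core, was modest, and with no step at the amine to lean on the working assumption is that the naphthalen-1-yl compound stays near compound 1, with a wide range to cover either direction. The step of a 1.0-fold lower number from compound 1 to compound 3 (0.02 log units; within the scatter) is therefore expected to lie within the scatter. For compound 3 in this assay the estimate is 5000 nM, in the range 1500 nM to 16000 nM.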

Compound 3, half-maximal inhibitory concentration: 8930 nM
Estimate against measurement, compound 3: 1.8-fold (0.25 log units) below, and the stated range covers the measured number.
By their numbers in this assay, from the lowest: compounds 1 and 3 (each within the scatter of the next); then compound 2.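

Naphthalen-1-yl in place of 4-bromophenyl on the amine nitrogen gives the first reading at this position in this assay, with a 1.7-fold higher number from compound 1 to compound 3 (0.23 log units; within the scatter) and the two compounds not separated. The entering group has 10 heavy atoms and 2 six-membered aromatic rings, while the leaving group has 7 heavy atoms, one such ring and the bromine, so this exchange of aryl groups on the core of compound 1 leaves the number within the scatter, unlike the step on the oxygen, a 4.6-fold higher number from compound 1 to compound 2 (0.66 log units; beyond the scatter). No measurement on hand explains why the number holds across this change.

Going by these compounds alone, the single pair cannot show what the bromine and the second ring each contribute, since both differ at once, so a plain phenyl or a 4-chlorophenyl on the same nitrogen would be needed to separate them. Also open, going by these compounds, are whether a non-aromatic group such as a butyl chain or a cyclohexyl is accepted on that nitrogen, and whether naphthalen-1-yl behaves the same way on the core of compound 2.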